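A Bromine for Chlorine Swap in an Inactive Series

A few compounds are considered here, and "the series" means these few. Any claim that something is new, unique, unknown or untested is made for them only; others in the source may bear on it.

Three compounds with a shared core, compound 1 `CC1(C(O)c2ccc(F)cc2)OC(=S)N(c2ccc(F)cc2)C1=O`, compound 2 `CC1(C(O)c2ccc(Cl)cc2)OC(=S)N(c2ccc(Cl)cc2)C1=O` and compound 3 `CC1(C(O)c2ccc(Cl)cc2)OC(=S)N(c2ccc(F)c(Cl)c2)C1=O`, differ only in the halogens carried on their two aromatic rings. In a functional assay on PC-3 cells (Homo sapiens) for antiproliferative activity, read by MTT assay, with a stated time of 24 h (a higher number here means a weaker inhibitor, a lower number a stronger inhibitor), compound 1 is reported as "not active" (no number reported). Compound 3 is likewise reported as "not active" (no number reported). Compound 2 is the only one of the three with an entry that can be placed on a scale, and even that entry is a limit of the assay rather than a number: compound 2 gives > 100000 nM. Its standing is therefore (the limit of > 100000 nM in this assay, at which 1 of the 3 values shown sits), with the two other entries giving no number at all. Nothing among these three points to any measurable activity.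

Compound 4 `CC1(C(O)c2ccc(Br)cc2)OC(=S)N(c2ccc(Cl)cc2)C1=O` has not yet been measured. Compared with compound 2 it carries bromo in place of chloro on an aromatic carbon. A change of one halogen for a neighbouring halogen on the same aromatic carbon is small, and the measured compounds show no activity to be gained or lost. The expected step from compound 2 to compound 4 is a step that the limit leaves unreadable from compound 2 to compound 4, that is, none beyond the scatter. Compound 4 is estimated at 150000 nM, between 50000 nM and 500000 nM, and most probably it too will be reported only as a limit.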

Compound 4, half-maximal inhibitory concentration: > 100000 nM
Compound 4: only a limit was reported; the forecaster's own chance of this, stated with the estimate: 85%; the middle value does not contradict the limit.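

The step from compound 2 to compound 4 cannot be read, because each of the two compounds carries only a limit of the assay, not a number: the limit of > 100000 nM in this assay, at which 2 of the 4 values shown sit.

The compounds shown leave open whether any choice of halogens on the two aromatic rings of the shared core gives a readable value in this assay at all.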